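The compounds below may be only part of what the source reports. "The series", "measured", "known", "first", "only" and "open" are said of these compounds alone.

Among the compounds with values here, in a functional assay on MCF7 cells (Homo sapiens) for inhibition, read by MTT assay, with a stated time of 5 days (a higher number here means a weaker inhibitor, a lower number a stronger inhibitor), two compounds on a shared core have numbers so far. Compound 1 (`Cc1cc(Nc2nc(NCc3ccccc3Cl)nc3[nH]ncc23)n[nH]1`) gives 4130 nM, and compound 2 (`Cc1cc(Nc2nc(NCc3ccc(C#N)cc3)nc3[nH]ncc23)n[nH]1`) gives 6060 nM. These two values lie within the scatter of each other, so compound 2 stands together with compound 1, with no order between them.

Compound 3 (`COc1ccc(CNc2nc(Nc3cc(C)[nH]n3)c3cn[nH]c3n2)cc1`) departs from compound 2 at a single place: methoxy in place of cyano on an aromatic carbon. In words, this is methoxy in place of cyano on an aromatic carbon, so 4-cyanophenyl becomes 4-methoxyphenyl.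

Within the data shown here, the one measured step that bears on this change exchanged 2-chlorophenyl for 4-cyanophenyl: a 1.5-fold higher number from compound 1 to compound 2 (0.17 log units; within the scatter). Among the measured compounds shown here, that step stayed within the scatter, but it is the only guide, and no measured compound carries methoxy. No step beyond the scatter is therefore expected in this assay, and no direction can be firmly expected. The estimated step is a 1.2-fold lower number from compound 2 to compound 3 (0.08 log units; within the scatter). For compound 3 the expected value is 5000 nM, with an estimated range from 2000 nM to 12000 nM.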

Compound 3, half-maximal inhibitory concentration: 3320 nM
The estimate for compound 3 lay 1.5-fold (0.18 log units) above the measured number; the range from low to high includes it.
By their numbers in this assay, from the lowest: compounds 3, 1 and 2 (each within the scatter of the next).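

In this assay, the aromatic carbon that carried cyano in compound 2 now carries methoxy, a group with the same count of heavy atoms and hydrogen-bond acceptors but a different atom bound to the ring, and the result is a small step (a 1.8-fold lower number from compound 2 to compound 3 (0.26 log units; within the scatter)). The step from the ortho-free comparison with the chlorinated compound is equally small (a 1.2-fold lower number from compound 1 to compound 3 (0.09 log units; within the scatter)), so 2-chlorophenyl, 4-cyanophenyl and 4-methoxyphenyl all stand together, with no order among compounds 1, 2 and 3, and this exchange of a nitrile for an ether-type group at this position produced no step beyond the scatter. No measured evidence is available to explain this result.

The compounds shown leave open whether this position stays as flat for a group of another kind, such as an amine, a carboxylic acid or a longer chain in place of methoxy. They also leave open whether any change on this ring, rather than elsewhere on the shared core, can move the number beyond the scatter at all.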